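Pyridine Isomer Swap on a Trifluoromethyl Anilide Core

The source may report more compounds than this note shows. Statements on the series, on what has been measured and on what is new or still open speak of the compounds shown alone.

Compound 1 `O=C(Nc1cc(C(F)(F)F)ccc1NC1CCCCC1)c1ccncc1` and compound 2 `O=C(Nc1cc(C(F)(F)F)ccc1NC1CCCCC1)c1cccnc1` share a core that carries a cyclohexylamino group; compound 3 `O=C(Nc1cc(C(F)(F)F)ccc1N1CCCC1)c1ccncc1` and compound 4 `O=C(Nc1cc(C(F)(F)F)ccc1N1CCCC1)c1cccnc1` carry instead (pyrrolidin-1-yl in place of cyclohexylamino on an aromatic carbon). In a functional assay on NALM-6 cells (Homo sapiens) for cytotoxicity, read by MTT assay, with a stated time of 48 h (on this read-out lower numbers stand for stronger inhibition and higher numbers for weaker inhibition), compound 1 gives 59000 nM, and compound 2 gives 52300 nM. The change pyridin-3-yl in place of pyridin-4-yl on a carbonyl carbon therefore produced a 1.1-fold lower number from compound 1 to compound 2 (0.05 log units; within the scatter). For compound 3 the assay gave no number: compound 3 is reported as "not active" (no number reported). The same change, (pyridin-3-yl in place of pyridin-4-yl on a carbonyl carbon), links compound 3 to compound 4. Among the compounds with values here, since the one measured instance of this change stayed within the scatter, compound 4 is expected to behave much like compound 3, and the assay may again return no number. Compound 4 is estimated at 150000 nM, with a range from 50000 nM to 500000 nM.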

Compound 4, half-maximal inhibitory concentration: "not active" (no number reported)
No number was reported for compound 4; the estimate stays without a comparison.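

Compound 3 and compound 4 both came back without a number, so no step can be read between them. Nothing shown offers a reason for this. The compounds shown leave open how far the pyridine isomer swap matters with pyrrolidin-1-yl on the shared core.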